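Swapping methoxy for cyano on a dinitro diaryl ether

This account rests on a few compounds, and the source may have more. Where it says the series, first, only, none or still open, it means among the compounds named here.

Compound 1 `Cc1cc(C)c(Oc2cc(Nc3ccc(C#N)cc3)c(N)cc2[N+](=O)[O-])c(C)c1`: 32200 nM
Compound 2 `COc1ccc(Nc2cc(Oc3c(C)cc(C)cc3C)c([N+](=O)[O-])cc2[N+](=O)[O-])cc1`: > 59100 nM

In an ADME assay on H9 cells (Homo sapiens) for cytotoxicity, read by XTT assay, with a stated time of 6 days (a higher number here means that more compound is tolerated, a lower number that less compound is tolerated), compound 1 gives 32200 nM. For compound 2 only a limit is known in this assay, > 59100 nM, so its true value is not a number. Compound 3 `Cc1cc(C)c(Oc2cc(Nc3ccc(C#N)cc3)c([N+](=O)[O-])cc2[N+](=O)[O-])c(C)c1` is not yet measured; it differs from compound 2 by cyano in place of methoxy on an aromatic carbon. Among the measured compounds shown here, no step between measured compounds is available, so the step of an at least 1.3-fold lower number from compound 2 to compound 3 (0.11 log units; that floor lies within the scatter) is expected to stay within the usual scatter. Compound 3 is expected to give about 45000 nM, in a range from 20000 nM to 80000 nM, with a fair chance that this assay again reports only a limit.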

Compound 3, half-maximal cytotoxic concentration: > 59800 nM
Compound 3: a limit, no number (the forecaster's own chance of this, stated with the estimate: 40%); at least 1.3-fold (0.12 log units) between middle value and limit.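

In this assay compound 3 gives only a limit, > 59800 nM. The change from methoxy to cyano, para to a large group, cannot be read because both of its ends are limits: the limit of > 59800 nM in this assay, at which 1 of the 3 values shown sits. Nitro in place of amino on an aromatic carbon gives an at least 1.8-fold higher number from compound 1 to compound 3 (0.26 log units; that floor lies within the scatter), so this step shows no firm shift either.

Going by these compounds, what a carboxylic acid or an ethoxy group at the cyano position would give in this assay stays open. On these data alone, the true values of compound 2 and compound 3 also stay open.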